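Estimating Cytotoxicity of a Dimethylphenyl Analogue from One Step

A few compounds are considered here, and "the series" means these few. Any claim that something is new, unique, unknown or untested is made for them only; others in the source may bear on it.

Measured compounds:
Compound 1 `Cc1ccc(C(=O)c2cc(Cl)ccc2Oc2ccnc(Nc3ccc(C#N)cc3)n2)cc1` gives 1710 nM.
Compound 2 `Cc1cc(C)cc(C(=O)c2cc(Cl)ccc2Oc2ccnc(Nc3ccc(C#N)cc3)n2)c1` gives 28800 nM.
Compound 3 `Cc1ccc(C(=O)c2cc(Cl)ccc2Oc2nc(Nc3ccc(C#N)cc3)ncc2C)cc1` gives only a limit, >= 830 nM.

All three were tested in an ADME assay on MT4 cells (Homo sapiens) for cytotoxicity, read by MTT assay, with a stated time of 5 days; on this read-out lower numbers stand for higher toxicity in this test and higher numbers for lower toxicity in this test. Compound 1 and compound 2 share everything except the group on the carbonyl carbon, and the step of a 17-fold higher number from compound 1 to compound 2 (1.23 log units; beyond the scatter) shows that exchanging 4-methylphenyl for 3,5-dimethylphenyl there moves the number far upward, toward lower toxicity. For compound 3 the measurement is a boundary of this assay and not a number. Because of the limit of >= 830 nM in this assay, at which 1 of the 3 values shown sits, the step that the limit leaves unreadable from compound 1 to compound 3 cannot be sized, so compound 3 stands only as a range on this read-out.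

Compound 4 `Cc1cc(C)cc(C(=O)c2cc(Cl)ccc2Oc2nc(Nc3ccc(C#N)cc3)ncc2C)c1` has not been measured. It differs from compound 3 by 3,5-dimethylphenyl in place of 4-methylphenyl on a carbonyl carbon. For the measured compounds named here, the one measured step with the same change is a 17-fold higher number from compound 1 to compound 2 (1.23 log units; beyond the scatter), which was large and upward. The same change applied to compound 3 is therefore expected to give a step that the limit leaves unreadable from compound 3 to compound 4 in this assay, with wide uncertainty since compound 3 is known only as a limit. Compound 4 is accordingly estimated at 20000 nM, within a range from 3000 nM to 80000 nM.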

Compound 4, half-maximal cytotoxic concentration: 13400 nM
For compound 4 the middle estimate is 1.5-fold (0.17 log units) above the measured one; low and high end bracket the measured number.
By their numbers in this assay, from the lowest: compound 1; then compound 4; then compound 2.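

Compound 4 gives the first readable measure in this assay of adding a methyl in place of hydrogen on an aromatic carbon of the shared core. With 3,5-dimethylphenyl on the carbonyl carbon, this change gives a 2.1-fold lower number from compound 2 to compound 4 (0.33 log units; beyond the scatter), a modest move toward higher toxicity in this test that lies beyond the usual scatter, though it is smaller than the large step seen on the carbonyl side, a 17-fold higher number from compound 1 to compound 2 (1.23 log units; beyond the scatter). The steps that touch compound 3 still cannot be read, as compound 3 stands only as a limit: the limit of >= 830 nM in this assay, at which 1 of the 4 values shown sits.

As far as these compounds go, whether the exchange of 4-methylphenyl for 3,5-dimethylphenyl has the same size with and without the added methyl stays open, and the methyl step rests on a single pair of compounds, so nothing here shows how it behaves with 4-methylphenyl on the carbonyl carbon. From the compounds shown here alone, how the number would move with an ethyl group or an amine in place of that methyl on the aromatic carbon is also open.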